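A few compounds are considered here, and "the series" means these few. Any claim that something is new, unique, unknown or untested is made for them only; others in the source may bear on it.

Measured in a functional assay on cells (Homo sapiens) for antiproliferative activity, read by MTT assay, with a stated time of 48 h; on this read-out higher numbers stand for weaker inhibition and lower numbers for stronger inhibition:

- Compound 1 `CCCn1c(N)c(-c2nc3ccccc3[nH]2)c2nc(C#N)c(C#N)nc21`: > 50000 nM
- Compound 2 `N#Cc1nc2c(-c3nc4ccccc4[nH]3)c(N)n(CCCO)c2nc1C#N`: > 50000 nM

In this assay, compound 2 gives > 50000 nM, which is a limit and not a number. Compound 1 also gives only a limit, so neither compound has a measured potency. Both stand at the limit of > 50000 nM in this assay, at which 2 of the 2 values shown sit.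

The next compound is compound 3 `N#Cc1nc2c(-c3nc4ccccc4[nH]3)c(N)n(CCCN3CCCCC3)c2nc1C#N`, which differs from compound 2 on the propyl chain: 3-hydroxypropyl gives way to 3-(piperidin-1-yl)propyl. piperidin-1-yl in place of hydroxy on a saturated chain carbon, three bonds along the chain from an aromatic nitrogen

For the measured compounds named here, the only measured step that bears on this place is a step that the two limits leave unreadable from compound 1 to compound 2, and it offers no size to carry over. The expectation therefore rests on the structural change alone and is loosely held. Any number for compound 3 would have to lie on the stronger side of the limit of > 50000 nM in this assay, at which 2 of the 2 values shown sit, and a further limit reading remains quite possible. The expected change in this assay is a modest one towards stronger inhibition, estimated as an at least 2.5-fold lower number from compound 2 to compound 3 (0.39 log units; beyond the scatter). For compound 3 the estimated value is 20000 nM, with an expected range of 4000 nM to 50000 nM.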

Compound 3, half-maximal inhibitory concentration: 6230 nM
Estimate against measurement, compound 3: 3.2-fold (0.51 log units) above; the measured number falls inside the stated range.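

In this assay compound 3 gives 6230 nM, the first actual number among the compounds shown, whereas the earlier step, which cannot be read, had shown nothing about this position. Placing piperidin-1-yl in place of hydroxy on a saturated chain carbon, three bonds along the chain from an aromatic nitrogen, gives an at least 8.0-fold lower number from compound 2 to compound 3 (0.90 log units; beyond the scatter), and setting the same group against hydrogen there gives an at least 8.0-fold lower number from compound 1 to compound 3 (0.90 log units; beyond the scatter). Each of these steps starts from a limit, and the end of the propyl chain is now seen to affect this read-out, with compound 3 alone having left the level where the other two compounds stay: the limit of > 50000 nM in this assay, at which 2 of the 3 values shown sit.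

On these data alone, with a single compound carrying a measured number, it remains open whether the change follows from the ring of piperidin-1-yl or from its nitrogen, and a morpholin-4-yl group or an open-chain dimethylamino group at the same chain end would bear on that. As far as these compounds go, it is equally open how the value would respond to a shorter ethyl or a longer butyl chain carrying piperidin-1-yl.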